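This account rests on a few compounds, and the source may have more. Where it says the series, first, only, none or still open, it means among the compounds named here.

Working notes on the series.

Among the measured compounds shown here, the core of compound 1 `COc1cccc(OC)c1OCCNCCOc1ccccc1OCc1cccc(Cl)c1` gives 0.0501 nM in an assay on CHO cells for displacement of a labelled ligand from Alpha-1D adrenergic receptor (Homo sapiens) (a lower number here means a stronger inhibitor, a higher number a weaker inhibitor), the lowest of the three numbers measured so far. Compound 2 `COc1cccc(OC)c1OCCNCCOc1ccccc1OCc1cccc(C)c1` gives 0.2 nM, and compound 3 `COc1ccccc1COc1ccccc1OCCNCCOc1c(OC)cccc1OC` gives 2 nM. The measured steps are a 4.0-fold higher number from compound 1 to compound 2 (0.60 log units; beyond the scatter) and a 40-fold higher number from compound 1 to compound 3 (1.60 log units; beyond the scatter), with a 10-fold higher number from compound 2 to compound 3 (1.00 log units; beyond the scatter) between the two weaker compounds.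

Compound 4 `COc1ccc(COc2ccccc2OCCNCCOc2c(OC)cccc2OC)cc1` is not yet measured. It differs from compound 1 in one place: 4-methoxyphenyl in place of 3-chlorophenyl on a saturated chain carbon bound to an oxygen on an aromatic ring.

The step that bears most directly on this change is a 40-fold higher number from compound 1 to compound 3 (1.60 log units; beyond the scatter), where a methoxyphenyl group replaced the chlorophenyl on the same chain carbon and the number rose by a large margin. The step of a 4.0-fold higher number from compound 1 to compound 2 (0.60 log units; beyond the scatter) shows that even a small change on that ring costs potency. For the measured compounds named here, no measured pair separates the two methoxyphenyl groups from each other, so the position effect is unknown. A loss beyond the scatter is therefore expected for compound 4, of a size estimated at a 12-fold higher number from compound 1 to compound 4 (1.08 log units; beyond the scatter), smaller than the step to compound 3 only by assumption. Compound 4 is expected to give about 0.6 nM, within a range of 0.1 nM to 4 nM.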

Compound 4, inhibition constant: 0.1 nM
Compound 4: the middle estimate sits 6.0-fold (0.78 log units) above what was measured; measured number inside the range.
By their numbers in this assay, from the lowest: compounds 1, 4 and 2 (each within the scatter of the next, the first and the last beyond it); then compound 3.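

Moving the methoxy group from 2-methoxyphenyl to 4-methoxyphenyl on the saturated chain carbon bound to an oxygen on an aromatic ring gives a 20-fold lower number from compound 3 to compound 4 (1.30 log units; beyond the scatter), so in this assay the large loss seen at compound 3 does not extend to both methoxyphenyl groups shown. The 4-methoxyphenyl group also stays level with the two smaller-substituted groups, with a 2.0-fold higher number from compound 1 to compound 4 (0.30 log units; within the scatter) and a 2.0-fold lower number from compound 2 to compound 4 (0.30 log units; within the scatter). The position therefore accepts a methoxy-bearing ring, and it is the 2-methoxyphenyl group that stands apart among the four compounds.

No measurement at hand gives a reason for this difference between the two methoxyphenyl groups. Still open, from the compounds shown here alone, is whether 3-methoxyphenyl stays with the 4-methoxyphenyl group or falls with the 2-methoxyphenyl group, and how 4-chlorophenyl or a ring carrying a carboxylic acid would read here.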